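The source may report more compounds than this note shows. Statements on the series, on what has been measured and on what is new or still open speak of the compounds shown alone.

Working notes on the chain length of the ester side arm. Compound 1 (`CCOC(=O)c1c(-c2cccc(Oc3ccccc3)c2)[nH]c2cc(OC)ccc2c1=O`) gives > 22000 nM in an ADME assay on HEK293 cells (Homo sapiens) for cytotoxicity, read by luminescence, with a stated time of 72 h (on this read-out higher numbers stand for an effect only at larger amounts of compound and lower numbers for an effect already at smaller amounts), as a limit of the assay. Compound 2 (`CCOC(=O)c1c(-c2cccc(Oc3c(C)cccc3C)c2)[nH]c2cc(OC)c(F)cc2c1=O`) gives > 22000 nM here, likewise a limit. Compound 3 (`COc1ccc2c(=O)c(C(=O)OCCCN(C)C)c(-c3cccc(Oc4ccccc4)c3)[nH]c2c1`) gives > 22000 nM as well, so it stands only at a limit. The whole set sits there (the limit of > 22000 nM in this assay, at which 3 of the 3 values shown sit). Compound 4 (`COc1ccc2c(=O)c(C(=O)OCCCCCCN(C)C)c(-c3cccc(Oc4ccccc4)c3)[nH]c2c1`) differs from compound 3 as follows (3-(dimethylamino)propyl in place of dimethylamino on a saturated chain carbon, three bonds along the chain from an oxygen next to a carbonyl group): 3-(dimethylamino)propyl in place of dimethylamino on a saturated chain carbon, three bonds along the chain from an oxygen next to a carbonyl group. Going by the values given here, the one measured step on this chain is a step that the two limits leave unreadable from compound 1 to compound 3 and sets no size. No step beyond the scatter is therefore expected in this assay and no direction is favoured. The expected step is an at least 1.1-fold lower number from compound 3 to compound 4 (0.04 log units; that floor lies within the scatter) on this estimate. Compound 4 is expected at 20000 nM with an estimated range of 8000 nM to 40000 nM and may again report only a limit.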

Compound 4, half-maximal effective concentration: > 22000 nM
Compound 4: only a limit was reported (the forecaster's own chance of this, stated with the estimate: 60%); at least 1.1-fold (0.04 log units) between middle value and limit.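

The new steps among compound 1, compound 3 and compound 4 cannot be read, as each value is only a limit: the limit of > 22000 nM in this assay, at which 4 of the 4 values shown sit.

The compounds shown leave open whether any ester side arm length produces a measurable effect in this assay.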